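The source may hold more compounds than are shown below. What is called first, only, known or untested is meant among the compounds shown, and "the series" means these compounds.

Of the compounds shown here, two built on the same core have been measured. Compound 1 `Nc1nc2[nH]c(CCSCC(=O)N[C@@H](CCC(=O)O)C(=O)O)cc2c(=O)[nH]1` and compound 2 `Nc1nc2[nH]c(CCSCCC(=O)N[C@@H](CCC(=O)O)C(=O)O)cc2c(=O)[nH]1` differ only in the length of the chain that leads to the amide. In a functional assay on KB cells (Homo sapiens) for antiproliferative activity, read by MTT assay, with a stated time of 72 h, in the presence of a further agent that is not named here (a higher number here means a weaker inhibitor, a lower number a stronger inhibitor), compound 1 gives 373 nM. In this assay compound 2 gives 324 nM. On these two numbers compound 2 sits at the low end, but its gap to compound 1 lies within the scatter of repeated measurements, so the two cannot be told apart.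

Compound 3 `Nc1nc2[nH]c(CCSCCC(=O)NCc3ccncc3)cc2c(=O)[nH]1` keeps the core and the chain of compound 2 but carries a different group on the amide nitrogen: (pyridin-4-yl)methyl in place of 1,3-dicarboxypropyl on an amide-type nitrogen. For the measured compounds named here, the 1,3-dicarboxypropyl group is shared by both measured compounds, so nothing measured shows what its removal does, and no step between measured compounds exists to guide the expectation. Without such a precedent, the step of a 9.3-fold higher number from compound 2 to compound 3 (0.97 log units; beyond the scatter) is expected to go toward a weaker inhibitor, clearly beyond the scatter. Compound 3 is expected to give about 3000 nM, with a range from 800 nM to 15000 nM.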

Compound 3, half-maximal inhibitory concentration: 45600 nM
Beside the measured number, compound 3's estimate is 15-fold (1.18 log units) below it; measured number outside the range, above it.
By their numbers in this assay, from the lowest: compounds 2 and 1 (each within the scatter of the next); then compound 3.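

In this assay, replacing 1,3-dicarboxypropyl with (pyridin-4-yl)methyl on the amide-type nitrogen gives a 140-fold higher number from compound 2 to compound 3 (2.15 log units; beyond the scatter), so the group at this position has a large effect on the read-out. The earlier pair could not show this: both compounds carry 1,3-dicarboxypropyl and differ only in the chain leading to the amide, and compound 1 at 373 nM and compound 2 at 324 nM lie within the scatter of each other, whereas this single change on the amide nitrogen moves the number far beyond the scatter. No measurement shown here explains the size of this step.

The change removes the carboxylic acids and the defined stereocentre and adds an aromatic ring all at once, so this one step cannot show which of these differences matters. A compound with a single carboxylic acid on the amide nitrogen, or one with a benzyl group there, would help to separate these contributions, and the same is true of a 4-carboxybenzyl group, which keeps an acid alongside an aromatic ring.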